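The source may report more compounds than this note shows. Statements on the series, on what has been measured and on what is new or still open speak of the compounds shown alone.

In a physicochemical assay for solubility, in phosphate buffer, at pH 7.4 (on this read-out lower numbers stand for lower solubility and higher numbers for higher solubility), compound 1 `OCCC1CCN(c2nccnc2OC2CN(c3ccc4ccccc4n3)C2)CC1` gives 84000 nM. Compound 2 `Cc1ccc(-c2nccnc2OC2CN(c3ccc4ccccc4n3)C2)cc1` reports only a limit, < 1000 nM, so its position is a bound and not a number. Among the measured compounds shown here, the one measured step at this place is an at least 84-fold lower number from compound 1 to compound 2 (1.92 log units; beyond the scatter), which is large and beyond the scatter, but it involves a different group. Compound 3 `Cc1ncccc1-c1nccnc1OC1CN(c2ccc3ccccc3n2)C1` has 2-methylpyridin-3-yl in place of 4-methylphenyl on an aromatic carbon. This is a smaller exchange, so a moderate rise in this assay is expected, an estimated at least 4.0-fold higher number from compound 2 to compound 3 (0.60 log units; beyond the scatter). Compound 3 is estimated at 4000 nM, with an expected range of 800 nM to 25000 nM.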

Compound 3, solubility: 253000 nM
For compound 3 the middle estimate is 63-fold (1.80 log units) below the measured one; the whole stated range lies below it.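

At this aromatic carbon, 2-methylpyridin-3-yl in place of 4-methylphenyl keeps 7 heavy atoms and brings in 1 nitrogen, yet this assay shows an at least 250-fold higher number from compound 2 to compound 3 (2.40 log units; beyond the scatter). The 4-(2-hydroxyethyl)piperidin-1-yl group is not needed for a high number at this place, with a 3.0-fold higher number from compound 1 to compound 3 (0.48 log units; beyond the scatter). For compound 2 the first of these steps rests on a limit and not on a number: the limit of < 1000 nM in this assay, at which 1 of the 3 values shown sits.

Open, from the compounds shown here alone, is whether the entering nitrogen or the changed place of the methyl carries the step. Also open, going by these compounds, is how plain phenyl, unmethylated pyridin-3-yl or a carboxylic acid-bearing phenyl would read here.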